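A few compounds are considered here, and "the series" means these few. Any claim that something is new, unique, unknown or untested is made for them only; others in the source may bear on it.

Measured in a functional assay (Platelet, plasma) for inhibition, with Homo sapiens as the target; on this read-out lower numbers stand for stronger inhibition and higher numbers for weaker inhibition:
- compound 1 `N#Cc1cc2c(nc1N1CCC(C(=O)NS(=O)(=O)Cc3ccc(Cl)cc3)CC1)COC2=O`: 4420 nM
- compound 2 `CC1(C(=O)NS(=O)(=O)c2ccc(Cl)s2)CCN(c2nc3c(cc2C#N)C(=O)OC3)CC1`: 1640 nM
- compound 3 `N#Cc1cc2c(nc1N1CCC(C(=O)NS(=O)(=O)Cc3ccccc3)CC1)CCOC2=O`: > 300000 nM

Compound 3 reaches only a limit of this assay, not a number, as the limit of > 300000 nM in this assay, at which 1 of the 3 values shown sits, shows. Among the two numbers that remain, compound 1 has the higher one; compound 2 sits a step below it, and that gap lies beyond the usual scatter. Compound 4 `N#Cc1ccc(CS(=O)(=O)NC(=O)C2CCN(c3nc4c(cc3C#N)C(=O)OC4)CC2)cc1` differs from compound 1 in one place: cyano in place of chloro on an aromatic carbon. The change sits on an aromatic carbon of a six-membered aromatic ring of carbon only, para to a large group, so that 4-chlorobenzyl becomes 4-cyanobenzyl. Among the compounds with values here, no measured pair here shows this exact exchange, so its effect in this assay is open. Given that compound 1 gives 4420 nM, a modest drift toward weaker inhibition is expected, of roughly a 1.5-fold higher number from compound 1 to compound 4 (0.17 log units; within the scatter). Compound 4 is therefore estimated at 6500 nM, within a range from 2000 nM to 20000 nM.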

Compound 4, half-maximal inhibitory concentration: 8900 nM
For compound 4 the middle estimate is 1.4-fold (0.14 log units) below the measured one; low and high end bracket the measured number.
By their numbers in this assay, from the lowest: compound 2; then compounds 1 and 4 (each within the scatter of the next). At a limit, above all of these: compound 3.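

In this assay, the exchange of chloro for cyano, on an aromatic carbon of a six-membered aromatic ring of carbon only, para to a large group, gives a 2.0-fold higher number from compound 1 to compound 4 (0.30 log units; within the scatter). Within the data shown here, this is the first step that can be read at this position, and it shows that 4-chlorobenzyl and 4-cyanobenzyl cannot be told apart on this read-out, even though the cyano adds a heavy atom and a hydrogen-bond acceptor. Nothing given here accounts for this step.

From the compounds shown here alone, whether this tolerance extends to other groups at this position stays open, since a methoxy, an amine or a carboxylic acid there could read quite differently. Going by these compounds, it also stays open how a plain hydrogen at this position would read on the core of compound 1.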